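Swapping the Ring on the Amide Nitrogen

The compounds below may be only part of what the source reports. "The series", "measured", "known", "first", "only" and "open" are said of these compounds alone.

Compound 1 `O=C(NCCCCc1ccccc1)c1cccc(C2SCC(=O)N2c2cccc(F)c2)c1`: 92%
Compound 2 `COc1ccccc1N1C(=O)CSC1C(=O)NCCCCc1ccccc1`: 60%
Compound 3 `COc1cc(F)ccc1N1C(=O)CSC1c1cccc(C(=O)NCCCCc2ccccc2)c1`: 92%

In a functional assay on MG-63 cells (Homo sapiens) for inhibition, read by CCK-8 assay, with a stated time of 72 h, tested at 1 uM (on this read-out lower numbers stand for less inhibition and higher numbers for more inhibition at the one concentration tested (going by the name of the read-out)), compound 3 gives 92%, level with compound 1 at the digits shown and together the highest of the three numbers; compound 2 gives 60%, a lower number beyond the scatter. Compound 4 `O=C(NCCCCc1ccccc1)c1cccc(C2SCC(=O)N2c2ccccc2F)c1` carries 2-fluorophenyl in place of 4-fluoro-2-methoxyphenyl on an amide-type nitrogen in a ring. Among the compounds with values here, only one measured step touches this position, no change at the digits printed from compound 1 to compound 3 (within the scatter), and it shows that exchanging one fluorinated ring for another on this nitrogen left the read-out unchanged. On that basis no step beyond the scatter is expected here, a number 4 percentage points lower from compound 3 to compound 4 (within the scatter). Compound 4 is therefore expected to give 88%, with a range from 75% to 97%.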

Compound 4, a percentage reported as inhibition, at one concentration (the size of the read-out at that concentration, not a potency): 92%
The estimate for compound 4 lay 4 percentage points below the measured number; the measured number falls inside the stated range.
By their numbers in this assay, from the lowest: compound 2; then compounds 1, 3 and 4 (each within the scatter of the next).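

Placing 2-fluorophenyl on this nitrogen gives no change at the digits printed from compound 3 to compound 4 (within the scatter) in this assay and no change at the digits printed from compound 1 to compound 4 (within the scatter) as well. Within the data shown here, the read-out therefore held both when the methoxy group was gone and when the fluorine sat elsewhere on the ring, which the single earlier step could not show. Nothing measured here explains why the read-out held. The compounds shown leave open whether an amine or a carboxylic acid on this ring would keep the read-out level, and whether lower concentrations would separate these compounds.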